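Pyridin-2-yl to thiazolyl: estimating compound 4 in this assay

The compounds below may be only part of what the source reports. "The series", "measured", "known", "first", "only" and "open" are said of these compounds alone.

In a physicochemical assay for solubility, read by nephelometry, measured as kinetic solubility, at pH 2.0 (on this read-out lower numbers stand for lower solubility and higher numbers for higher solubility), compound 2 `CC(C)(C)c1cc(C(=O)Nc2ccccn2)n(Cc2ccccc2)n1` gives 25 ug/mL, the lower of the two numbers recorded, and its nearest neighbour is compound 1 `COc1ccc(C(=O)Nc2nc(CN)cs2)cc1`; in this assay compound 1 gives 50 ug/mL, a gap that stays within the usual scatter. Compound 3 `NCc1csc(NC(=O)c2cccnn2)n1` reaches only a limit of the assay, > 100 ug/mL. Compound 4 `CN(C)Cc1csc(NC(=O)c2cc(C(C)(C)C)nn2Cc2ccccc2)n1` has not yet been measured; it differs from compound 2 by 4-((dimethylamino)methyl)-1,3-thiazol-2-yl in place of pyridin-2-yl on an amide-type nitrogen. Within the data shown here, no measured pair differs in exactly this way, so the step must be judged from the values at hand. Since compound 1 gives 50 ug/mL, the step of a 3.0-fold higher number from compound 2 to compound 4 (0.48 log units; beyond the scatter) is expected to be an increase somewhat beyond the scatter. Compound 4 is therefore estimated at 75 ug/mL, within a range from 30 ug/mL to 100 ug/mL.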

Compound 4, solubility: > 100 ug/mL
Compound 4 ended at the assay's limit (the forecaster's own chance of this, stated with the estimate: 35%); at least 1.3-fold (0.12 log units) between middle value and limit.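

At this amide-type nitrogen, 4-((dimethylamino)methyl)-1,3-thiazol-2-yl in place of pyridin-2-yl gives, in this assay, an at least 4.0-fold higher number from compound 2 to compound 4 (0.60 log units; beyond the scatter). Among these compounds, no pair among the earlier compounds differed in one place, and this is the only step that can be read. The value of compound 4 is a limit and not a number, which makes the step a lower bound with its full size unread: the limit of > 100 ug/mL in this assay, at which 2 of the 4 values shown sit.

The step changes the ring and adds the dimethylaminomethyl group together, and the compounds shown do not separate the two. From the compounds shown here alone, how an unsubstituted 1,3-thiazol-2-yl or a pyridin-2-yl bearing a dimethylaminomethyl group would read on this core remains open.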